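Amide nitrogen substituent and MDCK cytotoxicity

A few compounds are considered here, and "the series" means these few. Any claim that something is new, unique, unknown or untested is made for them only; others in the source may bear on it.

Measured compounds:
compound 1 `CCC(=O)Nc1cc(C(=O)Nc2ccc(Br)cc2)ccc1OC`: 90.4 uM
compound 2 `CCC(=O)Nc1cc(C(=O)NC2CCC2)ccc1OC`: > 724 uM

In an ADME assay on MDCK cells (Canis lupus familiaris) for cytotoxicity, read by cytopathic effect, with a stated time of 48 h (on this read-out lower numbers stand for higher toxicity in this test and higher numbers for lower toxicity in this test), compound 1 gives 90.4 uM. For compound 2 only a limit is known in this assay, > 724 uM; this is the limit at which the measurement stops (the limit of > 724 uM in this assay, at which 1 of the 2 values shown sits). Among the compounds with values here, the one measured step, an at least 8.0-fold higher number from compound 1 to compound 2 (0.90 log units; beyond the scatter), thus sits on this limit and is open-ended.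

Compound 3 `CCC(=O)Nc1cc(C(=O)Nc2ccccn2)ccc1OC` differs from compound 2 in one place: pyridin-2-yl in place of cyclobutyl on an amide-type nitrogen. This change runs in the direction opposite to the measured step, putting an aromatic ring back on the amide-type nitrogen in place of the cyclobutyl ring, though a different aromatic ring from the 4-bromophenyl of compound 1. Within the data shown here, the measured step of an at least 8.0-fold higher number from compound 1 to compound 2 (0.90 log units; beyond the scatter) is the only guide, and it suggests that returning to an aromatic ring is expected to move the number back down toward compound 1, so a step of an at least 2.4-fold lower number from compound 2 to compound 3 (0.38 log units; beyond the scatter) is expected. Compound 3 is therefore estimated at 300 uM in this assay, with a range of 100 uM to 724 uM, the upper end reaching the limit.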

Compound 3, half-maximal toxic concentration: > 668 uM
Compound 3 ended at the assay's limit; the forecaster's own chance of this, stated with the estimate: 35%; at least 2.2-fold (0.34 log units) between middle value and limit.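

In this assay compound 3 reads > 668 uM, which is a limit of the assay and not a number. The change to pyridin-2-yl gives an at least 7.3-fold higher number from compound 1 to compound 3 (0.86 log units; beyond the scatter), so a high reading on the amide-type nitrogen is not confined to the non-aromatic cyclobutyl ring, and among these three compounds the low number belongs to the 4-bromophenyl group and not to aromatic rings as such. Compound 2 and compound 3 both stand at limits, so the step between them cannot be read and neither can be placed above the other: the limit of > 668 uM in this assay, at which 1 of the 3 values shown sits.

Still open, from the compounds shown here alone, is whether the low number of compound 1 follows the bromine atom or the phenyl ring itself, a question that a plain phenyl group on the same amide-type nitrogen would help to separate. Also open, going by these compounds, is how far the true readings of compound 2 and compound 3 lie past their limits, so the full size of the gain over compound 1 stays unknown for both.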